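Lengthening the amide chain from compound 3 to compound 4

A few compounds are considered here, and "the series" means these few. Any claim that something is new, unique, unknown or untested is made for them only; others in the source may bear on it.

Measured so far in a physicochemical assay for lipophilicity (on this read-out higher numbers stand for higher lipophilicity and lower numbers for lower lipophilicity), for this series
compound 1 `CCNC(=O)c1ccc(S(N)(=O)=O)cc1` gives 0.03
compound 2 `CCCCNC(=O)c1ccc(S(N)(=O)=O)cc1` gives 1.05
compound 3 `CCCCCNC(=O)c1ccc(S(N)(=O)=O)cc1` gives 1.54

Compound 3 at 1.54 stands highest of the three, beyond the scatter from both others. Compound 4 `CCCCCCNC(=O)c1ccc(S(N)(=O)=O)cc1` is unmeasured and differs from it by methyl in place of hydrogen on a saturated chain carbon, five bonds along the chain from an amide-type nitrogen with methyl in place of hydrogen on a saturated chain carbon, five bonds along the chain from an amide-type nitrogen.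

Among the measured compounds shown here, the closest precedent is the modest step of a number 0.49 log units higher from compound 2 to compound 3 (beyond the scatter) for the same methyl-for-hydrogen change, four bonds along the chain. For the measured compounds named here, the large steps of a number 1.02 log units higher from compound 1 to compound 2 (beyond the scatter) and a number 1.51 log units higher from compound 1 to compound 3 (beyond the scatter) bring in ethyl and propyl and run the same way, and no compound so far goes against a rise with chain length. A modest rise beyond the scatter is therefore expected in this assay for the new compound. The expected step is a number 0.50 log units higher from compound 3 to compound 4 (beyond the scatter) on this estimate. The estimated value for compound 4 is 2.04 with an expected range of 1.8 to 2.3 on the same reasoning.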

Compound 4, partition coefficient: 2.05
Beside the measured number, compound 4's estimate is 0.01 log units below it; the range from low to high includes it.
By their numbers in this assay, from the lowest: compound 1; then compound 2; then compound 3; then compound 4.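

In this assay, methyl in place of hydrogen on a saturated chain carbon, five bonds along the chain from an amide-type nitrogen, gives a number 0.51 log units higher from compound 3 to compound 4 (beyond the scatter) and is again a modest step, as was a number 0.49 log units higher from compound 2 to compound 3 (beyond the scatter) for the same change four bonds along the chain. The wider comparisons run the same way, with ethyl four bonds along the chain giving a number 1.00 log units higher from compound 2 to compound 4 (beyond the scatter) and butyl two bonds along the chain giving a number 2.02 log units higher from compound 1 to compound 4 (beyond the scatter), so all four compounds now stand in order of chain length and none goes against that order. Nothing shown bears on the reason for this rise.

Going by these compounds, whether a longer chain continues the same rise remains open. Also open, on these data alone, is what an amine or a carboxylic acid in place of the added methyl would do to this read-out.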